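This account rests on a few compounds, and the source may have more. Where it says the series, first, only, none or still open, it means among the compounds named here.

Measured compounds:
Compound 1 `O=C(NCCO)c1cc2ccc(OCc3ccccc3)cc2oc1=O`: 14200 nM
Compound 2 `O=C(NCCNC(=O)c1cc2ccc(OCc3cccc(Br)c3)cc2oc1=O)c1cc2ccc(OCc3cccc(Br)c3)cc2oc1=O`: 5520 nM
Compound 3 `CCN(CC)c1ccc2cc(C(=O)NC(C)C)c(=O)oc2c1`: 73000 nM

In a functional assay on HeLa cells (Homo sapiens) for cytotoxicity, read by MTT assay, with a stated time of 72 h (on this read-out lower numbers stand for stronger inhibition and higher numbers for weaker inhibition), compound 3 stands highest of the three numbers; compound 1 is its nearest neighbour and compound 2 lies furthest from it, both with lower numbers beyond the scatter. Compound 4 `CCN(CC)c1ccc2cc(C(=O)N/N=C(/C)c3cccnc3)c(=O)oc2c1` has not yet been tested in this assay. It differs from compound 3 in one place: a group of 9 heavy atoms (7 carbon, 2 nitrogen; one six-membered aromatic ring with 1 hetero atom) in place of a group of 3 heavy atoms (3 carbon; no ring), on an amide-type nitrogen. For the measured compounds named here, no pair of measured compounds differs in a single place, so this step has no direct precedent; what can be said is that the largest structure, compound 2, shows the lowest number and the smallest amide substituent, in compound 3, the highest. A modest step toward a lower number is therefore expected, a 2.4-fold lower number from compound 3 to compound 4 (0.39 log units; beyond the scatter), of a size that may not clear the scatter. Compound 4 is estimated at 30000 nM, within a range from 8000 nM to 120000 nM.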

Compound 4, half-maximal inhibitory concentration: 70000 nM
Beside the measured number, compound 4's estimate is 2.3-fold (0.37 log units) below it, and the stated range covers the measured number.
By their numbers in this assay, from the lowest: compound 2; then compound 1; then compounds 4 and 3 (each within the scatter of the next).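

In this assay, the first step read at this amide-type nitrogen, isopropyl to the larger ring-bearing group, gives a 1.0-fold lower number from compound 3 to compound 4 (0.02 log units; within the scatter). For the compounds shown here, on this read-out, the added heavy atoms, aromatic ring and hydrogen-bond acceptors therefore leave the two compounds indistinguishable, a point the earlier compounds, which differ in more than one place, could not show. No measurement given here bears on why this is so. Still open, as far as these compounds go, is whether a primary amine or a carboxylic acid on this nitrogen would give a step beyond the scatter.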